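A few compounds are considered here, and "the series" means these few. Any claim that something is new, unique, unknown or untested is made for them only; others in the source may bear on it.

Working notes on the series in a functional assay on HCT-116 cells (Homo sapiens) for cytotoxicity; on this read-out higher numbers stand for weaker inhibition and lower numbers for stronger inhibition: compound 1 `COc1cc(N2CCN(C(=O)C3CCC(O)CC3)CC2)ccc1Nc1nc(NC2CCCCC2)c2nc[nH]c2n1` gives 15 nM, compound 2 `COc1cc(N2CCN(CC3CCOC3)CC2)ccc1Nc1nc(NC2CCCCC2)c2nc[nH]c2n1` gives 66 nM and compound 3 `COc1cc(N2CCC(CC(=O)N3CCOCC3)CC2)ccc1Nc1nc(NC2CCCCC2)c2nc[nH]c2n1` gives 36 nM. Compound 3 thus lies within the scatter of compound 2, while compound 1 has the lower number, beyond the scatter. Next is compound 4 `COc1cc(N2CCC(CC(=O)N3CCC(N(C)C)C3)CC2)ccc1Nc1nc(NC2CCCCC2)c2nc[nH]c2n1`, with 3-(dimethylamino)pyrrolidin-1-yl in place of morpholin-4-yl on a carbonyl carbon. Among the compounds with values here, the only measured step, a 4.4-fold higher number from compound 1 to compound 2 (0.64 log units; beyond the scatter), concerns a group on an amine nitrogen in a ring, not this place, so it informs only the width of the range. No step beyond the scatter is expected in this assay, and no direction is favoured. The estimated step is a 1.2-fold lower number from compound 3 to compound 4 (0.08 log units; within the scatter). For compound 4 the estimated value is 30 nM, with a range of 10 nM to 90 nM.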

Compound 4, half-maximal inhibitory concentration: 59 nM
Compound 4: middle estimate off by 2.0-fold (0.29 log units), on the low side; low and high end bracket the measured number.
By their numbers in this assay, from the lowest: compound 1; then compounds 3, 4 and 2 (each within the scatter of the next).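

Replacing morpholin-4-yl with 3-(dimethylamino)pyrrolidin-1-yl on a carbonyl carbon gives a 1.6-fold higher number from compound 3 to compound 4 (0.21 log units; within the scatter) in this assay, the only reading at this place among the compounds shown. This place therefore accepts a five-membered ring carrying a dimethylamino group in place of a six-membered ring with two hetero atoms, without a change beyond the scatter. No measurement bears on the origin of this result. Still open, as far as these compounds go, is whether a piperazin-1-yl group or an open-chain amine such as diethylamino on this carbonyl carbon would move the number beyond the scatter.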